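Oxygen substituent swap on the ring nitrogen, compound 3 to 4

The compounds below may be only part of what the source reports. "The series", "measured", "known", "first", "only" and "open" are said of these compounds alone.

Values in an assay on HEK293 cells for inhibition of N-acylethanolamine-hydrolyzing acid amidase (Homo sapiens), read by fluorescence, with stated times of 10 min and 50 min; a higher number here means a weaker inhibitor, a lower number a stronger inhibitor:
compound 1 `CN1C[C@H](NC(=O)OCCCCC2CCCCC2)C1=O`: 1980 nM
compound 2 `CON1C[C@H](NC(=O)OCCCCC2CCCCC2)C1=O`: 16 nM
compound 3 `C[C@H]1[C@H](NC(=O)OCCCCC2CCCCC2)C(=O)N1OCCCCC1CCCCC1`: 3470 nM

Compound 3 gives the highest of the three numbers in this assay. Its nearest neighbour is compound 1, whose number is lower but within the scatter, so no order between compound 1 and compound 3 can be stated. Compound 2 lies far off with a much lower number, beyond the scatter. Among the measured compounds shown here, the single measured step, a 120-fold lower number from compound 1 to compound 2 (2.09 log units; beyond the scatter), is large and concerns the substituent on the ring nitrogen itself.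

Compound 4 `C[C@H]1[C@H](NC(=O)OCCCCC2CCCCC2)C(=O)N1Oc1ccccc1S(C)(=O)=O` differs from compound 3 on the oxygen that sits on that ring nitrogen: 2-(methylsulfonyl)phenyl in place of 4-cyclohexylbutyl on an oxygen. For the measured compounds named here, no measured pair in this set changes the group on this oxygen; the step from compound 1 to compound 2 exchanges what is attached to the nitrogen and gives no direct read on replacing one oxygen substituent by another. Going by the values given here, both compound 3 and compound 4 keep the methyl on the ring carbon and the full carbamate side chain, so the only anchor is the value of compound 3 itself. Among the compounds with values here, with no bearing step, the expectation for compound 4 is a number close to that of compound 3, with a wide range either way.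

Compound 4 is therefore estimated at 2500 nM, with a range from 500 nM to 12000 nM. This estimate corresponds to an expected step of a 1.4-fold lower number from compound 3 to compound 4 (0.14 log units; within the scatter).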

Compound 4, half-maximal inhibitory concentration: 6 nM
Compound 4: middle estimate off by 420-fold (2.62 log units), on the high side; the whole stated range lies above it.
By their numbers in this assay, from the lowest: compound 4; then compound 2; then compounds 1 and 3 (each within the scatter of the next).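

In this assay, the group on the oxygen attached to the amide-type nitrogen in a ring strongly affects the reading: 2-(methylsulfonyl)phenyl in place of 4-cyclohexylbutyl gives a 580-fold lower number from compound 3 to compound 4 (2.76 log units; beyond the scatter). The earlier step, methoxy in place of methyl on that nitrogen with a 120-fold lower number from compound 1 to compound 2 (2.09 log units; beyond the scatter), changed the atom bound to the nitrogen, whereas here the oxygen stays and the exchange of its substituent alone produces a large step. The two groups have the same heavy-atom count but differ in other ways, with an aromatic ring in place of a non-aromatic one, a sulfonyl group with its hydrogen-bond acceptors in place of none, and no four-carbon chain, and no available data indicate which of these differences accounts for the step.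

From the compounds shown here alone, it remains open whether the step follows the aromatic ring or the methylsulfonyl group, a question that a plain phenyl on the same oxygen would address. Going by these compounds, it is also open how much the methyl on the ring carbon contributes alongside 2-(methylsulfonyl)phenyl, which a hydrogen in its place would show.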